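Removing One Chain Double Bond

A few compounds are considered here, and "the series" means these few. Any claim that something is new, unique, unknown or untested is made for them only; others in the source may bear on it.

In a functional assay on MDA-MB-231 cells (Homo sapiens) for antiproliferative activity, read by MTT assay (a lower number here means a stronger inhibitor, a higher number a weaker inhibitor), compound 1 `CC/C=C\C/C=C\C/C=C\CCCCCCCc1cc(=O)c2c(O)cc(OCOC)c(C)c2o1` gives 6790 nM, compound 2 `CC/C=C\C/C=C\C/C=C\CCCCCCCc1cc(=O)c2c(O)cc(O)cc2o1` gives 6790 nM and compound 3 `CC/C=C\C/C=C\C/C=C\CCCCCCCc1cc(=O)c2c(O)cc(OCOC)cc2o1` gives 6790 nM, so compound 3 stands level with both. Compound 4 `CCCCC/C=C\C/C=C\CCCCCCCc1cc(=O)c2c(O)cc(OCOC)cc2o1` differs from compound 3 in its long chain: butyl in place of but-1-en-1-yl on a saturated chain carbon bound to a double-bonded chain carbon. Among the compounds with values here, no measured step touches this chain, so the only guides are two changes on the shared core: no change at the digits printed from compound 1 to compound 3 (within the scatter) and no change at the digits printed from compound 2 to compound 3 (within the scatter). Both lie within the scatter, which is weak evidence for a chain change, but nothing points to a real shift. The expected step is a 1.0-fold higher number from compound 3 to compound 4 (0.00 log units; within the scatter), none beyond the scatter. Compound 4 is estimated at 6800 nM, with an expected range of 3400 nM to 13500 nM.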

Compound 4, half-maximal inhibitory concentration: > 87000 nM
Compound 4 was reported as a limit; the forecaster's own chance of this, stated with the estimate: 10%; middle value at least 12-fold (1.10 log units) away from the limit.
By their numbers in this assay, from the lowest: compounds 1, 2 and 3 (each within the scatter of the next). At a limit, above all of these: compound 4.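

The long chain proves sensitive where the core did not: in this assay, butyl in place of but-1-en-1-yl on a saturated chain carbon bound to a double-bonded chain carbon gives an at least 12-fold higher number from compound 3 to compound 4 (1.10 log units; beyond the scatter). The steps among compound 1, compound 2 and compound 3, all on the core, stayed within the scatter. The value of compound 4 is only a limit, so the true size of this step is not known: the limit of > 87000 nM in this assay, at which 1 of the 4 values shown sits.

Going by these compounds, whether removing a different chain double bond would do the same remains open. So does how a fully saturated chain or a longer chain would behave.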